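The compounds below may be only part of what the source reports. "The series", "measured", "known", "first", "only" and "open" are said of these compounds alone.

Measured in a functional assay on HCT-116 cells (Homo sapiens) for inhibition, read by MTT assay, with a stated time of 72 h; on this read-out higher numbers stand for weaker inhibition and lower numbers for stronger inhibition:
Compound 1 `CNC(=O)CCCCCCCn1nc(-c2cnc3[nH]ccc3c2)c2c(N)ncnc21`: 6760 nM
Compound 2 `Nc1ncnc2c1c(-c1cnc3[nH]ccc3c1)nn2CC(=O)NO`: > 150000 nM, a limit of the assay and not a number
Compound 3 `Nc1ncnc2c1c(-c1cnc3[nH]ccc3c1)nn2CCCCCCCCCC(=O)NO`: 18700 nM

Of the two values that are true numbers, compound 3 has the higher, which means the weaker inhibition. The gap is modest: a 2.8-fold higher number from compound 1 to compound 3 (0.44 log units; beyond the scatter).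

Compound 4 `Nc1ncnc2c1c(-c1cnc3[nH]ccc3c1)nn2CCCC(=O)NO` keeps the shared core and the hydroxycarbamoyl end of compound 3 but carries a shorter chain. The change is hydroxycarbamoyl in place of 6-(hydroxycarbamoyl)hexyl on a saturated chain carbon, three bonds along the chain from an aromatic nitrogen. The resulting chain is still longer than that of compound 2.

Within the data shown here, two measured steps bear on this change, and both also alter the chain end. With a long chain kept, the step to compound 3 stayed modest, as shown above. Cutting the chain down much further gave a large step: an at least 22-fold higher number from compound 1 to compound 2 (1.34 log units; beyond the scatter). On that evidence, shortening the chain of compound 3 is expected to raise the number in this assay by clearly more than the scatter. The result could also end at the limit of > 150000 nM in this assay, at which 1 of the 3 values shown sits.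

For compound 4 the expected step is a 3.7-fold higher number from compound 3 to compound 4 (0.57 log units; beyond the scatter). The estimated value for compound 4 is 70000 nM, with an expected range of 30000 nM to 150000 nM.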

Compound 4, half-maximal inhibitory concentration: > 150000 nM
Compound 4: only a limit was reported; the forecaster's own chance of this, stated with the estimate: 35%; middle value at least 2.1-fold (0.33 log units) from the limit.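

Keeping the hydroxycarbamoyl end and placing hydroxycarbamoyl in place of 6-(hydroxycarbamoyl)hexyl, on a saturated chain carbon three bonds along the chain from an aromatic nitrogen, gives an at least 8.0-fold higher number from compound 3 to compound 4 (0.90 log units; beyond the scatter) in this assay. This is the first readable step shown in which the chain is shortened while its end group stays the same, so the weaker inhibition here goes with chain length alone, and the same shortened chain also compares poorly with the methylcarbamoyl chain, with an at least 22-fold higher number from compound 1 to compound 4 (1.34 log units; beyond the scatter). Compound 4 gives a limit and not a number, as does compound 2, so the step between these two cannot be read, and the two shortest chains shown cannot be ranked against each other: the limit of > 150000 nM in this assay, at which 2 of the 4 values shown sit.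

Going by these compounds, how far past the limit compound 4 truly lies stays open, and so does where between the chains of compound 4 and compound 3 the inhibition starts to fall away. Also open, on these data alone, is whether a carboxylic acid at the chain end, or a longer chain than that of compound 3, would give a lower number on this core.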